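Extending a methyl into a pyrazole on the aryl arm

A few compounds are considered here, and "the series" means these few. Any claim that something is new, unique, unknown or untested is made for them only; others in the source may bear on it.

The compounds measured so far:
- compound 1, `COc1ccc(-c2cc3nccc(-c4cc(OC)c(OC)c(OC)c4)n3n2)cc1N`: 283 nM in a functional assay on HeLa cells (Homo sapiens) for inhibition, read by CCK-8 assay, with a stated time of 48 h; a higher number here means a weaker inhibitor, a lower number a stronger inhibitor
- compound 2, `COc1cc(-c2ccnc3cc(-c4ccc(C)cc4)nn23)cc(OC)c1OC`: 21 nM in this assay
- compound 3, `COc1ccc(-c2cc3nccc(-c4cc(OC)c(OC)c(OC)c4)n3n2)cc1F`: 236 nM in this assay

Compound 2 stands lowest of the three numbers, so it is the strongest inhibitor here: its gap to compound 3 is an 11-fold higher number from compound 2 to compound 3 (1.05 log units; beyond the scatter) and the other gap is a 13-fold lower number from compound 1 to compound 2 (1.13 log units; beyond the scatter). Compound 4, `COc1cc(-c2ccnc3cc(-c4ccc(-c5cnn(C)c5)cc4)nn23)cc(OC)c1OC`, keeps the shared core of compound 2 and changes only the aryl arm: 1-methyl-1H-pyrazol-4-yl in place of methyl on an aromatic carbon.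

Among the compounds with values here, no measured step swaps one small group for a larger ring at this place, so nothing bears on it directly. The two steps that change this arm, a 13-fold lower number from compound 1 to compound 2 (1.13 log units; beyond the scatter) and an 11-fold higher number from compound 2 to compound 3 (1.05 log units; beyond the scatter), were both large, which shows that this arm matters, but both replaced the whole ring rather than extending it. The expected step from compound 2 to compound 4 is therefore modest and uncertain, a 1.7-fold higher number from compound 2 to compound 4 (0.22 log units; within the scatter). Compound 4 is estimated at 35 nM, in the range 8 nM to 150 nM.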

Compound 4, half-maximal inhibitory concentration: 1830 nM
Compound 4: middle estimate off by 52-fold (1.72 log units), on the low side; measured number above the stated range.
By their numbers in this assay, from the lowest: compound 2; then compounds 3 and 1 (each within the scatter of the next); then compound 4.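

Extending the arm, rather than replacing its whole ring, is not harmless at this position: putting 1-methyl-1H-pyrazol-4-yl in place of methyl, para to a large group, gives an 87-fold higher number from compound 2 to compound 4 (1.94 log units; beyond the scatter) in this assay. Within the data shown here, that is the largest step so far, so the arm's effect on this number does not depend on a change of the whole ring. The change adds heavy atoms, a five-membered aromatic ring and hydrogen-bond acceptors all at once, and nothing available explains the loss or ties it to any one of these.

As far as these compounds go, it remains open whether a small group such as ethyl or methoxy would keep the number of compound 2 . A phenyl ring or a pyrazole lacking its methyl could show whether any added ring at this place gives a similar step.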